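Amide variation from compound 3

The source may report more compounds than this note shows. Statements on the series, on what has been measured and on what is new or still open speak of the compounds shown alone.

Three measured compounds share one core, read in a functional assay on MIA PaCa-2 cells (Homo sapiens) for inhibition, read by MTT assay, with a stated time of 7 days; a lower number here means a stronger inhibitor, a higher number a weaker inhibitor. Compound 1 `O=C([C@@H]1CCCN(S(=O)(=O)c2ccc(S(=O)(=O)N3CC[C@@H](O)C3)cc2)C1)N1CCC(F)(F)CC1` gives 210 nM. Compound 2 `O=C([C@@H]1CCCN(S(=O)(=O)c2ccc(S(=O)(=O)C3COC3)cc2)C1)N1CCC(F)(F)CC1` gives 110 nM. Compound 3 `CCN(CC)S(=O)(=O)c1ccc(S(=O)(=O)N2CCC[C@@H](C(=O)NC3COC3)C2)cc1` gives 2340 nM, the highest of the three numbers; its nearest neighbour is compound 1 and its furthest is compound 2, both gaps lying beyond the scatter. For the measured compounds named here, the only single-point step measured so far, a 1.9-fold lower number from compound 1 to compound 2 (0.28 log units; within the scatter), concerns the sulfonyl sulfur and lies within the scatter.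

Compound 4 `CCN(CC)S(=O)(=O)c1ccc(S(=O)(=O)N2CCC[C@@H](C(=O)N3CCC(COC)CC3)C2)cc1` is not yet measured. It differs from compound 3 in one place: 4-(methoxymethyl)piperidin-1-yl in place of (oxetan-3-yl)amino on a carbonyl carbon. Going by the values given here, no measured step covers this amide change directly. Compounds 1 and 2 carry a tertiary amide on the same carbonyl and sit well below compound 3, but each also differs from compound 3 at the sulfonyl sulfur, so their gap cannot be assigned to the amide alone. Among the compounds with values here, since the one step measured at the sulfonyl side stayed within the scatter, the amide change is expected to carry most of that gap. Compound 4 is therefore expected to come in with a lower number than compound 3, the estimated step being a 6.7-fold lower number from compound 3 to compound 4 (0.83 log units; beyond the scatter). The estimate for compound 4 is 350 nM, with a range from 120 nM to 1000 nM.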

Compound 4, half-maximal inhibitory concentration: 250 nM
Estimate against measurement, compound 4: 1.4-fold (0.15 log units) above; the range from low to high includes it.
By their numbers in this assay, from the lowest: compounds 2, 1 and 4 (each within the scatter of the next, the first and the last beyond it); then compound 3.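

In this assay, for the compounds shown here, the carbonyl carbon gives the first one-place step that lies beyond the scatter (a 9.4-fold lower number from compound 3 to compound 4 (0.97 log units; beyond the scatter)), so the amide substituent alone can move the number, with the remainder of compound 3 held constant. Going by these compounds alone, the only earlier one-place step, at the sulfonyl sulfur, stayed within the scatter, and the earlier gaps to compound 3 involved changes in more than one place. The heavy-atom count, the ring and the amide hydrogen all change together in this step, and no measurement here explains the shift or assigns it to any one of these differences.

The compounds shown leave open whether the loss of the amide hydrogen or the larger ring carries the step: (N-methyl-oxetan-3-yl)amino would keep the four-membered ring without that hydrogen, and piperidin-3-ylamino or cyclohexylamino would pair a six-membered ring with it. From the compounds shown here alone, the role of the methoxymethyl chain is also open, and unsubstituted piperidin-1-yl or 4-(2-methoxyethyl)piperidin-1-yl on the same carbonyl would test it against the shared core.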